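Working notes on the step from compound 3 to compound 4

The source may hold more compounds than are shown below. What is called first, only, known or untested is meant among the compounds shown, and "the series" means these compounds.

Measured in a physicochemical assay for solubility; a higher number here means a more soluble compound, a lower number a less soluble compound:
- compound 1 `COc1cc2nnc(C(N)=O)c(Nc3ccc(C)cc3F)c2cc1N1CCC(OC)CC1`: 2000 nM
- compound 2 `COc1cc2nnc(C(N)=O)c(Nc3ccc(C)cc3F)c2cc1N1C[C@@H](C)N[C@@H](C)C1`: 200000 nM
- compound 3 `COc1cc2nnc(C(N)=O)c(Nc3ccc(C)cc3F)c2cc1N1CCCN(C)CC1`: 54000 nM

Compound 3 stands second highest of the three numbers, below compound 2 and above compound 1. The next structure, compound 4 `COc1cc2nnc(C(N)=O)c(Nc3ccc(C)cc3F)c2cc1N1CCN(C)CC1`, carries 4-methylpiperazin-1-yl in place of 4-methyl-1,4-diazepan-1-yl on an aromatic carbon, ortho to a methoxy group: 4-methylpiperazin-1-yl in place of 4-methyl-1,4-diazepan-1-yl on an aromatic carbon.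

Three measured steps at this same carbon bear on the change. Two are large, and both replace the 4-methoxypiperidin-1-yl group: a 100-fold higher number from compound 1 to compound 2 (2.00 log units; beyond the scatter) and a 27-fold higher number from compound 1 to compound 3 (1.43 log units; beyond the scatter). The change to compound 4 involves no such group. Among the compounds with values here, the closest precedent is therefore the modest 3.7-fold lower number from compound 2 to compound 3 (0.57 log units; beyond the scatter), which also exchanges one of these replacement rings for another. A step of that size at most is expected in this assay, with no direction settled and most likely none beyond the scatter. The estimated step is a 1.1-fold higher number from compound 3 to compound 4 (0.05 log units; within the scatter). For compound 4 the expected value is 60000 nM, with an estimated range of 20000 nM to 180000 nM.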

Compound 4, solubility: 87000 nM
Beside the measured number, compound 4's estimate is 1.5-fold (0.16 log units) below it; the range from low to high includes it.
By their numbers in this assay, from the lowest: compound 1; then compounds 3 and 4 (each within the scatter of the next); then compound 2.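

In this assay, the seven-membered 4-methyl-1,4-diazepan-1-yl ring and the six-membered 4-methylpiperazin-1-yl ring are not separated at this aromatic carbon: a 1.6-fold higher number from compound 3 to compound 4 (0.21 log units; within the scatter), so this change of ring size has no resolved effect on the read-out. A third substituent also stands well clear of the 4-methoxypiperidin-1-yl group, with a 44-fold higher number from compound 1 to compound 4 (1.64 log units; beyond the scatter), while a 2.3-fold lower number from compound 2 to compound 4 (0.36 log units; beyond the scatter) shows that the two piperazine substituents, 3,5-dimethylpiperazin-1-yl and 4-methylpiperazin-1-yl, can still be told apart. No measured property is available to account for these steps.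

The compounds shown leave open how a morpholin-4-yl ring, with an oxygen in place of the second ring nitrogen, would compare with these substituents at the same carbon. They also leave open where an open-chain dimethylaminoethoxy group would fall.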